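The compounds below may be only part of what the source reports. "The series", "measured", "known", "first", "only" and "open" are said of these compounds alone.

Measured in a functional assay on cells (Cancer cell lines, Homo sapiens) for cytotoxicity, read by sulforhodamine B assay, with a stated time of 48 h; a higher number here means a weaker inhibitor of growth, a lower number a stronger inhibitor of growth:
compound 1 `COc1ccc(OC)c(-c2cc(-c3ccccc3)nn2-c2ccc(S(N)(=O)=O)cc2)c1`: 32900 nM
compound 2 `COc1ccc(OC)c(-c2cc(-c3ccccc3)nn2-c2ccc(S(=O)(=O)NC(C)=O)cc2)c1`: 44500 nM

Among the compounds with values here, compound 2 holds the highest of the two numbers in this assay; its nearest neighbour is compound 1, and the one measured step, a 1.4-fold higher number from compound 1 to compound 2 (0.13 log units; within the scatter), lies within the scatter. Compound 3 `CC(=O)NS(=O)(=O)c1ccc(-n2nc(-c3ccccc3)cc2C2=CC(=O)C=CC2=O)cc1` differs from compound 2 by a group of 8 heavy atoms (6 carbon, 2 oxygen; one six-membered non-aromatic ring of carbon only) in place of a group of 10 heavy atoms (8 carbon, 2 oxygen; one six-membered aromatic ring of carbon only), on an aromatic carbon. Within the data shown here, no measured step bears on this change: the only known step concerns the sulfonamide nitrogen, not the ring carried on the core. The expectation for compound 3 therefore rests on compound 2 alone and carries a wide range. In this assay compound 3 is estimated at 20000 nM, between 4000 nM and 80000 nM. The expected step is a 2.2-fold lower number from compound 2 to compound 3 (0.35 log units; beyond the scatter).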

Compound 3, concentration for total growth inhibition: 100000 nM
Compound 3: middle estimate off by 5.0-fold (0.70 log units), on the low side; the whole stated range lies below it.
By their numbers in this assay, from the lowest: compounds 1 and 2 (each within the scatter of the next); then compound 3.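

Within the data shown here, at this aromatic carbon, next to the ring nitrogen, replacing 2,5-dimethoxyphenyl with the non-aromatic six-membered carbon ring gives in this assay a 2.2-fold higher number from compound 2 to compound 3 (0.35 log units; beyond the scatter) and is the first step beyond the scatter. The position therefore responds to the group it carries, which the earlier step at the sulfonamide nitrogen could not show. Nothing measured here accounts for this change.

As far as these compounds go, whether a plain phenyl or a phenyl bearing an amine at this carbon would move the number remains open. Also open, from the compounds shown here alone, is whether the same exchange gives a similar step with the unsubstituted sulfonamide of compound 1.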